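A hydroxy group added to a methoxyphenyl ring

The source may hold more compounds than are shown below. What is called first, only, known or untested is meant among the compounds shown, and "the series" means these compounds.

Compound 1 `COc1cc(-n2c(-c3ccc4ccccc4c3)coc2=O)cc(OC)c1OC` and compound 2 `COc1ccc(-c2oc(O)nc2-c2cc(OC)c(OC)c(OC)c2)cc1` have both been measured in a functional assay on PC-3 cells (Homo sapiens) for inhibition; a lower number here means a stronger inhibitor, a higher number a weaker inhibitor. Compound 1 gives 3.1 nM. Compound 2 gives 20.1 nM, the higher of the two numbers and so the weaker inhibitor, a gap beyond the usual scatter. Compound 3 `COc1ccc(-c2oc(O)nc2-c2cc(OC)c(OC)c(OC)c2)cc1O` differs from compound 2 by hydroxy in place of hydrogen on an aromatic carbon, ortho to a methoxy group. Within the data shown here, no measured pair shows this exact change, so the size of the step is uncertain. A modest move toward a lower number is expected, a 2.5-fold lower number from compound 2 to compound 3 (0.40 log units; beyond the scatter). Compound 3 is expected to give 8 nM, within 2 nM to 30 nM.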

Compound 3, half-maximal inhibitory concentration: 6.4 nM
For compound 3 the middle estimate is 1.3-fold (0.10 log units) above the measured one; low and high end bracket the measured number.
By their numbers in this assay, from the lowest: compound 1; then compound 3; then compound 2.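

In this assay, the change from 4-methoxyphenyl to 3-hydroxy-4-methoxyphenyl gives a 3.1-fold lower number from compound 2 to compound 3 (0.50 log units; beyond the scatter), so a hydroxy group ortho to a methoxy group is not merely tolerated on this ring but gives a stronger inhibitor. This is the first step shown at this position, as the earlier compounds offered no pair differing in one place. Nothing available explains why this change lowers the number.

On these data alone, whether an amine or a fluorine at this same position would do the same remains open. So does whether the hydroxy group would give this step without the neighbouring methoxy group.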